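The source may hold more compounds than are shown below. What is called first, only, known or untested is meant among the compounds shown, and "the series" means these compounds.

Measured so far in a functional assay on SGC-7901 cells (Homo sapiens) for antiproliferative activity, read by MTT assay, with a stated time of 72 h; on this read-out higher numbers stand for weaker inhibition and lower numbers for stronger inhibition:

- compound 1, `CCOC(=O)c1cc(-c2cc(OC)c(OC)c(OC)c2)c(-c2ccc(OC)c([N+](=O)[O-])c2)s1`: 18100 nM
- compound 2, `CCOC(=O)c1cc(-c2cc(OC)c(OC)c(OC)c2)c(-c2ccc(OC)c(OCc3ccccc3)c2)s1`: this value is a limit of the assay, not a number: > 100000 nM
- compound 3, `CCOC(=O)c1cc(-c2ccc(OC)c([N+](=O)[O-])c2)c(-c2cc(OC)c(OC)c(OC)c2)s1`: 19400 nM

Compound 1 and compound 3 are built from the same atoms joined differently; the difference between the two cores is not broken down here. Their two numbers lie within the scatter of each other.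

From compound 1 to compound 2 the change is benzyloxy in place of nitro on an aromatic carbon. This gave an at least 5.5-fold higher number from compound 1 to compound 2 (0.74 log units; beyond the scatter). The size of that step is known only as a lower bound because of the limit of > 100000 nM in this assay, at which 1 of the 3 values shown sits.

Compound 4, `CCOC(=O)c1cc(-c2ccc(OC)c(OCc3ccccc3)c2)c(-c2cc(OC)c(OC)c(OC)c2)s1`, is not yet measured. It differs from compound 3 by benzyloxy in place of nitro on an aromatic carbon, the same change as from compound 1 to compound 2, at a place described in the same words.

Resting on compound 3 with 19400 nM and on the earlier step of an at least 5.5-fold higher number from compound 1 to compound 2 (0.74 log units; beyond the scatter), the step from compound 3 to compound 4 is expected to be a 5.2-fold higher number from compound 3 to compound 4 (0.71 log units; beyond the scatter). Compound 4 is therefore estimated at 100000 nM, with a likely range from 40000 nM to 300000 nM.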

Compound 4, half-maximal inhibitory concentration: > 100000 nM
Compound 4 ended at the assay's limit; the forecaster's own chance of this, stated with the estimate: 65%; the middle value lies on the limit itself.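

In this assay compound 4 gives > 100000 nM, which is a limit of the assay and not a number. Putting benzyloxy in place of nitro on an aromatic carbon gave an at least 5.1-fold higher number from compound 3 to compound 4 (0.71 log units; beyond the scatter), the same direction as on the core of compound 1, so in these two pairs the direction of the change carries over from one core to the other. What this does not show is whether the size of the step carries over as well, since each step is known only as a lower bound: the same change on two cores in this assay, an at least 5.5-fold higher number (0.74 log units; beyond the scatter) from compound 1 to compound 2 and an at least 5.1-fold higher number (0.71 log units; beyond the scatter) from compound 3 to compound 4; the limit leaves it open whether they differ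

The compounds shown leave open how an amine, a hydroxyl or an ethoxy group at the same place would behave, and so whether such a group would give a measurable number on either core, as nitro does, or reach the limit, as benzyloxy does. They also leave open whether the same change would go the same way if the ethyl ester were replaced by a carboxylic acid.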